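The compounds below may be only part of what the source reports. "The series", "measured", "known", "first", "only" and "open" are said of these compounds alone.

Measured compounds:
- compound 1 `CCC1C(=O)N(C)c2cnc(-n3ccc4cc(C(=O)NC(C)C)ccc43)nc2N1c1ccn(C)n1`; in an assay for inhibition of serine/threonine-protein kinase PLK2 (Homo sapiens), read by FRET and Z'-LYTE, with a stated time of 1 h (a lower number here means a stronger inhibitor, a higher number a weaker inhibitor), compound 1 gives 125 nM
- compound 2 `CCC1C(=O)N(C)c2cnc(-n3ccc4cc(C(=O)NC)ccc43)nc2N1c1ccn(C)n1`; in this assay compound 2 gives 218 nM
- compound 3 `CCCNC(=O)c1ccc2c(ccn2-c2ncc3c(n2)N(c2ccn(C)n2)C(CC)C(=O)N3C)c1`; in this assay compound 3 gives 207 nM

The three measured compounds share one core and differ only in the group carried on the amide-type nitrogen. On the numbers shown, compound 3 lies within the scatter of both of the others: its nearest neighbour is compound 2 and its furthest is compound 1, and neither gap exceeds the usual spread of repeated measurements. Compound 4 `CCNC(=O)c1ccc2c(ccn2-c2ncc3c(n2)N(c2ccn(C)n2)C(CC)C(=O)N3C)c1` is reached from compound 3 by the following change: hydrogen in place of methyl on a saturated chain carbon, two bonds along the chain from an amide-type nitrogen. Among the compounds with values here, three measured steps bear on this, all of them changes at the same amide-type nitrogen: a 1.7-fold higher number from compound 1 to compound 2 (0.24 log units; within the scatter), a 1.7-fold higher number from compound 1 to compound 3 (0.22 log units; within the scatter) and a 1.1-fold lower number from compound 2 to compound 3 (0.02 log units; within the scatter). None of these moved the number in this assay beyond the scatter, whether the group grew or shrank, and the change from compound 3 to compound 4 is of the same kind. Compound 4 is therefore expected to show no step beyond the scatter, a 1.0-fold lower number from compound 3 to compound 4 (0.01 log units; within the scatter). The estimate for compound 4 in this assay is 200 nM, with a range from 100 nM to 400 nM.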

Compound 4, half-maximal inhibitory concentration: 243 nM
The estimate for compound 4 lay 1.2-fold (0.08 log units) below the measured number; the measured number falls inside the stated range.
By their numbers in this assay, from the lowest: compounds 1, 3, 2 and 4 (each within the scatter of the next).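

With an ethyl group on the amide-type nitrogen, the propyl to ethyl change, which places hydrogen for methyl two bonds along the chain from that nitrogen, stays within the scatter in this assay (a 1.2-fold higher number from compound 3 to compound 4 (0.07 log units; within the scatter)). The new group also stays within the scatter of the methyl group (a 1.1-fold higher number from compound 2 to compound 4 (0.05 log units; within the scatter)) and of the isopropyl group (a 1.9-fold higher number from compound 1 to compound 4 (0.29 log units; within the scatter)), so the step from a branched to a shorter straight group does not pass the scatter either. Across the methyl, ethyl, propyl and isopropyl amides, all of the measured steps therefore remain within the scatter, and this position shows no measurable response to chain length or branching within these four compounds; nothing available bears on why the number stays this flat.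

The compounds shown leave open whether a longer chain such as butyl, or a chain ending in an amine or a carboxylic acid, would move the number beyond the scatter at this nitrogen. They also leave open whether a cyclopropyl group, or the unsubstituted amide with hydrogen in place of the alkyl group, would stay within it in this assay.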